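The source may report more compounds than this note shows. Statements on the series, on what has been measured and on what is new or still open speak of the compounds shown alone.

Series notes. Compound 1 `Cc1nc(S(C)(=O)=O)ccc1Oc1ncnc(OC2CCN(C(=O)OC(C)(C)C(F)(F)F)CC2)c1F` and compound 2 `Cc1nc(S(C)(=O)=O)ccc1Oc1ncnc(OC2CCN(C(=O)C(F)(F)F)CC2)c1F` share one core and differ only at a carbonyl carbon. In a functional assay on isolated protein for inhibition of Glucose-dependent insulinotropic receptor (Rattus norvegicus), read by HTRF and cAMP accumulation (a lower number here means a smaller maximal response, a higher number a larger maximal response), compound 1 gives 79%; compound 2 gives 76% in this assay. Going by the values given here, the step of a number 3 percentage points lower from compound 1 to compound 2 (within the scatter) is the only measured step so far. Of the two numbers measured, compound 2 carries the one nearer the bottom, but its gap to compound 1 is within the scatter, so no order between the two is established.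

Compound 3 `Cc1nc(S(C)(=O)=O)ccc1Oc1ncnc(OC2CCN(C(=O)c3noc(C(C)C)n3)CC2)c1F` is next. The change: 5-isopropyl-1,2,4-oxadiazol-3-yl in place of trifluoromethyl on a carbonyl carbon. Among the compounds with values here, the measured step of a number 3 percentage points lower from compound 1 to compound 2 (within the scatter) sits on the same carbonyl carbon and was within the scatter; no measured step covers an aromatic ring entering at this place. The expectation is therefore no step beyond the scatter in this assay, an estimated step of no change at the digits printed from compound 2 to compound 3 (within the scatter). Compound 3 is expected to give 76% in this assay, with a range of 62% to 90%.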

Compound 3, largest response reached (reported as efficacy), in percent of the reference or control that the assay uses: 81%
For compound 3 the middle estimate is 5 percentage points below the measured one; measured number inside the range.
By their numbers in this assay, from the lowest: compounds 2, 1 and 3 (each within the scatter of the next).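

With an aromatic ring now on the carbonyl carbon, the 5-isopropyl-1,2,4-oxadiazol-3-yl group in this assay gives a number 5 percentage points higher from compound 2 to compound 3 (within the scatter) and, set against 1-methyl-1-(trifluoromethyl)ethoxy, a number 2 percentage points higher from compound 1 to compound 3 (within the scatter) in the same read-out. Trifluoromethyl, 1-methyl-1-(trifluoromethyl)ethoxy and this five-membered aromatic ring, though they differ in size and in hydrogen-bond acceptors, are therefore not separated at this position in this assay on the shared core. No supporting measurement is available to explain this lack of separation.

From the compounds shown here alone, whether a primary amine, a carboxylic acid or a phenyl ring on this carbonyl carbon would give a step beyond the scatter remains open. Every step shown also sits at this one carbon, so the effect of changes elsewhere on the core remains open too.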